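Methoxy addition on the aminophenyl: compound 2 to compound 3

The source may report more compounds than this note shows. Statements on the series, on what has been measured and on what is new or still open speak of the compounds shown alone.

Measured compounds:
compound 1 `Cc1n[nH]c2ccc(-c3nc4cnc(N5CCC(C)CC5)cn4c3Nc3ccc(Cl)cc3)cc12` — 28%
compound 2 `COc1ccc(Nc2c(-c3ccc4[nH]nc(C)c4c3)nc3cnc(N4CCN(C)CC4)cn23)cc1` — 3.32%

In a functional assay on MV4-11 cells (Homo sapiens) for inhibition, with a stated time of 120 h, tested at 10 uM (on this read-out higher numbers stand for more inhibition at the one concentration tested (going by the name of the read-out) and lower numbers for less inhibition), compound 1 gives 28% and compound 2 gives 3.32%. Compound 2 thus stands at the bottom of the two numbers, with compound 1 beyond the scatter above it. Compound 3 `COc1ccc(Nc2c(-c3ccc4[nH]nc(C)c4c3)nc3cnc(N4CCN(C)CC4)cn23)cc1OC` differs from compound 2 by methoxy in place of hydrogen on an aromatic carbon. For the measured compounds named here, no measured pair shows this change, so its effect here is unknown. The step is expected to be small, a number 3.7 percentage points higher from compound 2 to compound 3 (within the scatter), not beyond the scatter. Compound 3 is estimated at 7%, with a range from 0% to 22%.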

Compound 3, a percentage reported as inhibition, at one concentration (the size of the read-out at that concentration, not a potency): 6.27%
Estimate against measurement, compound 3: 0.7 percentage points above, and the stated range covers the measured number.
By their numbers in this assay, from the lowest: compounds 2 and 3 (each within the scatter of the next); then compound 1.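

In this assay the change from 4-methoxyphenyl to 3,4-dimethoxyphenyl gives a number 3 percentage points higher from compound 2 to compound 3 (within the scatter), so this aromatic carbon, ortho to a methoxy group, takes a second methoxy with no change beyond the scatter. For the compounds shown here, this is the first one-place comparison, and it covers only this single substituent at this single carbon. No supporting measurement bears on this result.

Going by these compounds, whether an amine, a carboxylic acid or a longer alkoxy chain at this carbon would move the read-out remains open. Also open, on these data alone, is whether methoxy in place of hydrogen here would behave alike on compound 1 .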